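Removing the methoxymethyl group: what the cytotoxicity assay may show

The compounds below may be only part of what the source reports. "The series", "measured", "known", "first", "only" and "open" are said of these compounds alone.

Measured compounds:
Compound 1 `COCOc1cc(C2=C(c3cc(OC)c(OC)c(OC)c3)C(=O)CC2O[SiH2]C(C)(C)C)ccc1OC`: > 100 ug/mL
Compound 2 `COc1ccc(C2=C(c3cc(OC)c(OC)c(OC)c3)CC(O)C2=O)cc1N`: > 100 ug/mL
Compound 3 `COc1ccc(C2=C(c3cc(OC)c(OC)c(OC)c3)C(=O)C(O[SiH2]C(C)(C)C)C2)cc1`: > 100 ug/mL

In an ADME assay on HEK293 cells (Homo sapiens) for cytotoxicity, read by MTT assay, with a stated time of 72 h (a higher number here means a weaker inhibitor, a lower number a stronger inhibitor), compound 1 gives > 100 ug/mL, which is a limit of the assay rather than a measured number. The value of compound 2 in this assay is also a limit. The same holds for compound 3 in this assay. So compound 1 stands exactly where the other two stand: at the limit of > 100 ug/mL in this assay, at which 3 of the 3 values shown sit. For the measured compounds named here, no two measured compounds differ in only one place, so no measured step is available to lean on.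

Compound 4 `COc1ccc(C2=C(c3cc(OC)c(OC)c(OC)c3)C(=O)CC2O[SiH2]C(C)(C)C)cc1O` differs from compound 1 in a single spot: hydrogen in place of methoxymethyl on an oxygen on an aromatic ring. Cut one bond further out, the change reads methoxymethoxy to hydroxy.

With every known value sitting at the limit, the expected step is a step that the limit leaves unreadable from compound 1 to compound 4, with no direction beyond the usual scatter. Compound 4 is therefore estimated at 150 ug/mL, within 60 ug/mL to 400 ug/mL, and most likely the assay will again report only a limit.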

Compound 4, half-maximal inhibitory concentration: 42 ug/mL
Compound 4: the middle estimate sits 3.6-fold (0.55 log units) above what was measured; the whole stated range lies above it.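

Replacing methoxymethyl with hydrogen on this oxygen on the aromatic ring gives, in this assay, an at least 2.3-fold lower number from compound 1 to compound 4 (0.37 log units; beyond the scatter), so this one change moves the read-out beyond the usual scatter. Compound 4 gives 42 ug/mL, a true measured number. Compound 1, compound 2 and compound 3 all sit at a limit of the assay: the limit of > 100 ug/mL in this assay, at which 3 of the 4 values shown sit. The full size of the step cannot be read, and only its minimum is known.

The compounds shown leave open whether the free hydroxy is what matters, or whether another group on that oxygen, such as an ethyl or an acetyl group, would also bring the number down. This single pair also cannot tell whether the same change would have a similar effect on a different core.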